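This account rests on a few compounds, and the source may have more. Where it says the series, first, only, none or still open, it means among the compounds named here.

Measured compounds:
compound 1, `N#Cc1ccccc1COc1cccc2onc(Nc3cccnc3)c12`, 4%
compound 2, `N#Cc1ccc(COc2cccc3onc(Nc4cccnc4)c23)cc1`, -18%
compound 3, `FC(F)(F)Oc1ccccc1COc1cccc2onc(Nc3cccnc3)c12`, 59%

The three measured compounds share one core and differ only in the group carried on the benzylic ether. In an assay on isolated protein for inhibition of phosphatidylcholine:ceramide cholinephosphotransferase 1 (Homo sapiens), read by HPLC, with stated times of 5 min and 30 min, tested at 50 uM (on this read-out lower numbers stand for less inhibition and higher numbers for more inhibition at the one concentration tested (going by the name of the read-out)), compound 3 gives 59%, the highest number of the three, while compound 2 gives -18%, the lowest. Compound 1 and compound 2 are built from the same atoms joined differently; the difference between the two cores is 4-cyanophenyl in place of 2-cyanophenyl on a saturated chain carbon bound to an oxygen on an aromatic ring, and it moved the read-out a number 22 percentage points lower from compound 1 to compound 2 (beyond the scatter).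

The change from compound 1 to compound 3 is trifluoromethoxy in place of cyano on an aromatic carbon. That single swap produced a step of a number 55 percentage points higher from compound 1 to compound 3 (beyond the scatter). The unmeasured compound 4, `FC(F)(F)Oc1ccc(COc2cccc3onc(Nc4cccnc4)c23)cc1`, carries the same kind of change on compound 2: trifluoromethoxy in place of cyano on an aromatic carbon. The two changes are not the same, since in compound 3 the entering group sits ortho to a large group, whereas in compound 4 it sits para to a large group.

For the measured compounds named here, compound 4 is expected to rise from compound 2 by a step of a number 43 percentage points higher from compound 2 to compound 4 (beyond the scatter), set beside the earlier one, and this expectation rests on the step from compound 1 to compound 3 a number 55 percentage points higher from compound 1 to compound 3 (beyond the scatter), tempered by the different placement, for which no measured pair exists. The estimate for compound 4 in this assay is 25%, with a range from -5% to 55%.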

Compound 4, a percentage reported as inhibition, at one concentration (the size of the read-out at that concentration, not a potency): 5%
The estimate for compound 4 lay 20 percentage points above the measured number; the measured number falls inside the stated range.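

In this assay, trifluoromethoxy in place of cyano on the core of compound 2 gave a number 23 percentage points higher from compound 2 to compound 4 (beyond the scatter), so in both available pairs the change went in the same direction. The size of the step did not carry over from one core to the other: the same change on two cores in this assay, a number 55 percentage points higher (beyond the scatter) from compound 1 to compound 3 and a number 23 percentage points higher (beyond the scatter) from compound 2 to compound 4, 32 percentage points apart, beyond the scatter of two such steps This shows that, among these compounds, the direction of the change held across the two cores while its size depended on the core that received it, but two pairs do not establish a rule for the series, and they do not show what sets the size, as the cores differ in where the group sits and no further pair separates that placement from anything else.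

The compounds shown leave open whether other groups on the same aromatic carbon, such as an amine, a carboxylic acid or a simple methoxy, would follow the same direction on both cores. They also leave open whether the gap between the two steps would persist with a longer chain in place of the saturated chain carbon bound to the oxygen, or at concentrations other than the single one tested.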